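Swapping the Sulfur-Linked Aryl Group: From Compound 3 to Compound 4

The source may hold more compounds than are shown below. What is called first, only, known or untested is meant among the compounds shown, and "the series" means these compounds.

Compound 3 `Cc1cc(C)cc(SCc2ccc(/C=C/C(=O)Nc3ccccc3N)cc2)c1` stands lowest of the three measured compounds in a functional assay on A-375 cells (Homo sapiens) for inhibition, read by CCK-8 assay, with a stated time of 72 h, tested at 8 uM (on this read-out higher numbers stand for more inhibition of growth at the one concentration tested and lower numbers for less inhibition of growth), where compound 3 gives 2.49%. Its nearest neighbour on that scale is compound 2 `Nc1ccccc1NC(=O)c1ccc(CSc2ccc(C(F)(F)F)cn2)cc1`, which in this assay gives 5.34%, and the two numbers lie within the scatter of each other. For the measured compounds named here, compound 1 `Nc1ccccc1NC(=O)/C=C/c1ccc(CSc2ccc(F)cc2)cc1` gives 24.6% in this assay, and the only measured step that touches compound 3 is the one from compound 1: a number 22.1 percentage points lower from compound 1 to compound 3 (beyond the scatter).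

Compound 4 `Nc1ccccc1NC(=O)/C=C/c1ccc(CSc2ccc(C(F)(F)F)cn2)cc1` keeps the shared core of compound 3 and changes only the group on the sulfur: 5-(trifluoromethyl)pyridin-2-yl in place of 3,5-dimethylphenyl on a sulfur. Going by the values given here, no measured step covers this exact exchange on this core. Among the compounds with values here, the same 5-(trifluoromethyl)pyridin-2-yl group sits on the sulfur of compound 2, whose value is within the scatter of compound 3, while the fluorophenyl of compound 1 gave the one larger number. A small rise at most is therefore expected, as a number 5.5 percentage points higher from compound 3 to compound 4 (within the scatter), so compound 4 is estimated at 8% in this assay, expected between 0% and 22%.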

Compound 4, percent growth inhibition at one concentration: 3.96%
For compound 4 the middle estimate is 4 percentage points above the measured one, within the range that was stated.
By their numbers in this assay, from the lowest: compounds 3, 4 and 2 (each within the scatter of the next); then compound 1.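

On the sulfur of the shared core, 5-(trifluoromethyl)pyridin-2-yl and 3,5-dimethylphenyl cannot be told apart in this assay (a number 1.5 percentage points higher from compound 3 to compound 4 (within the scatter)). Measured against the 4-fluorophenyl group, however, the 5-(trifluoromethyl)pyridin-2-yl group gives a clear drop (a number 20.6 percentage points lower from compound 1 to compound 4 (beyond the scatter)), so two quite different groups on this sulfur now both fall well short of 4-fluorophenyl, where before only one had been seen to do so. Nothing measured here offers a reason for this difference.

Among these three groups, the 4-fluorophenyl group alone gives the larger number, but three groups cannot show what sets it apart. A plain phenyl or a 4-chlorophenyl group on the same sulfur would show whether that number depends on fluorine itself or holds for other groups of this kind.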